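Halogen Position on the Phenoxy Chain and Enzyme Inhibition

This account rests on a few compounds, and the source may have more. Where it says the series, first, only, none or still open, it means among the compounds named here.

Compound 3 `NC1=NC2(CCSCC2)N(OCCCOc2ccccc2Cl)C(N)=N1` is the reference point here. In an assay on isolated protein for inhibition of Dihydrofolate reductase (Homo sapiens), read by spectrophotometry, using NADPH, with stated times of 5 s and 6 min, tested at 50 uM (a higher number here means a stronger effect of the compound at the concentration tested, a lower number a weaker effect), compound 3 gives 89.6%. Compound 2 `NC1=NC2(CCSCC2)N(OCCCOc2ccccc2Br)C(N)=N1` gives 89.6% in this assay, and the step of no change at the digits printed from compound 2 to compound 3 (within the scatter) shows the two level at the digits reported. Compound 1 `NC1=NC2(CCSCC2)N(OCCCOc2cccc(Cl)c2)C(N)=N1` gives 88.8% in this assay, and the step of a number 0.8 percentage points higher from compound 1 to compound 3 (within the scatter) is likewise within the scatter, so the three measured compounds cannot be told apart on these numbers.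

Compound 4 `NC1=NC2(CCSCC2)N(OCCCOc2cccc(Br)c2)C(N)=N1` has not yet been measured. The change from compound 3 to compound 4 is 3-bromophenyl in place of 2-chlorophenyl on an oxygen on a saturated carbon. Going by the values given here, two measured steps bear on it: the move of the chlorine from the 3-position to the 2-position of the phenyl ring, a number 0.8 percentage points higher from compound 1 to compound 3 (within the scatter), and the exchange of bromo for chloro on the aromatic carbon, no change at the digits printed from compound 2 to compound 3 (within the scatter). Both steps were within the scatter, and compound 4 combines the reverse of each, so no step beyond the scatter is expected in this assay.

Compound 4 is therefore estimated to give 89% in this assay, with an expected range from 83% to 94%, which corresponds to an expected step of a number 0.6 percentage points lower from compound 3 to compound 4 (within the scatter).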

Compound 4, a percentage reported as inhibition, at one concentration (the size of the read-out at that concentration, not a potency): 86.5%
Compound 4: the middle estimate sits 2.5 percentage points above what was measured; the range from low to high includes it.
By their numbers in this assay, from the lowest: compounds 4, 1, 2 and 3 (each within the scatter of the next).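

With the 3-bromophenyl group in place, both halogens have now been read in both ring positions on the shared core, and in this assay the double change of 2-chlorophenyl to 3-bromophenyl gives a number 3.1 percentage points lower from compound 3 to compound 4 (within the scatter), while the change of 2-bromophenyl to 3-bromophenyl alone gives a number 3.1 percentage points lower from compound 2 to compound 4 (within the scatter). The last remaining single change, bromo in place of chloro on the 3-substituted phenyl, gives a number 2.3 percentage points lower from compound 1 to compound 4 (within the scatter), so neither the halogen nor its ring position produces a step that can be told from the scatter among these four compounds. The exchange of bromo and chloro also reads alike in the 2-substituted and 3-substituted phenyl series: the same change on two cores in this assay, no change at the digits printed (within the scatter) from compound 2 to compound 3 and a number 2.3 percentage points higher (within the scatter) from compound 4 to compound 1, 2.3 percentage points apart, within the scatter of two such steps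

These percentages come from a single concentration, so they tell only how strong the effect of each of the four compounds is at that concentration. Also open, on these data alone, is whether a methoxy group, a trifluoromethyl group or an amine on the phenyl ring, or a longer chain carrying the phenoxy group, would leave the read-out as undisturbed as the two halogens do.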